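Triazole nitrogen substituent swap in an antiproliferative series

A few compounds are considered here, and "the series" means these few. Any claim that something is new, unique, unknown or untested is made for them only; others in the source may bear on it.

Measured compounds:
compound 1, `O=c1c2ccc(C(F)(F)F)nc2ncn1Cc1cc(-c2ccc(Br)cc2)no1`, gives 710 nM in a functional assay on MDA-MB-231 cells (Homo sapiens) for antiproliferative activity, read by sulforhodamine B assay, with a stated time of 48 h; on this read-out higher numbers stand for weaker inhibition of growth and lower numbers for stronger inhibition of growth;
compound 2, `O=C(Cn1cc(COc2nc(-c3ccccc3)nc3nc(C(F)(F)F)ccc23)nn1)Nc1ccccc1`, gives 650 nM in this assay.

Compound 2 holds the lowest of the two numbers in this assay, but its nearest neighbour, compound 1, lies within the scatter of it, so the two cannot be ranked against each other. For the measured compounds named here, no pair of measured compounds differs in a single place, so no step is available.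

Compound 3, `COc1cc(-n2cc(COc3nc(-c4ccccc4)nc4nc(C(F)(F)F)ccc34)nn2)cc(OC)c1OC`, has not yet been measured in this assay. It differs from compound 2 by 3,4,5-trimethoxyphenyl in place of (phenylcarbamoyl)methyl on an aromatic nitrogen. The rest of the molecule is unchanged.

Going by the values given here, with no measured step to lean on, the expected step from compound 2 to compound 3 in this assay is only loosely bounded. Compound 3 is expected to land in the same general region as compound 2, the step being a 1.6-fold lower number from compound 2 to compound 3 (0.21 log units; within the scatter), with a leaning toward somewhat stronger inhibition of growth. The estimate for compound 3 in this assay is 400 nM, within a range from 80 nM to 2000 nM.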

Compound 3, concentration for 50% growth inhibition: 240 nM
For compound 3 the middle estimate is 1.7-fold (0.22 log units) above the measured one; the measured number falls inside the stated range.
By their numbers in this assay, from the lowest: compound 3; then compounds 2 and 1 (each within the scatter of the next).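

For the compounds shown here, the step is the first readable change at this position: in this assay, 3,4,5-trimethoxyphenyl in place of (phenylcarbamoyl)methyl on the aromatic nitrogen gives a 2.7-fold lower number from compound 2 to compound 3 (0.43 log units; beyond the scatter) with the rest of the molecule unchanged. The earlier compounds shown here offered no such single-place comparison, whereas this modest step, beyond the scatter, shows that the read-out responds to the group on this nitrogen and that the loss of the amide-bearing side chain is compatible with stronger inhibition of growth in this pair. No measurement shown bears on why the number moves, so the step stands only as an observation on one pair of compounds.

The compounds shown leave open whether the step belongs to the three methoxy groups or to the phenyl ring itself, a question that a plain phenyl or a 4-methoxyphenyl group on the same nitrogen would address. They also leave open how this position would respond to a quite different substituent, such as a benzyl group, a longer alkyl chain or a chain ending in an amine.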